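Dropping the Fluoro Substituent from a Sulfonyl-Triazole Naphthoquinone Imine

A few compounds are considered here, and "the series" means these few. Any claim that something is new, unique, unknown or untested is made for them only; others in the source may bear on it.

Compound 1 `Cc1ccc(S(=O)(=O)n2cc(COC3=C/C(=N\c4ccc(Br)cc4)c4ccccc4C3=O)nn2)cc1` gives 5400 nM in a functional assay on K562 cells (Homo sapiens) for cytotoxicity, read by MTT assay, with a stated time of 72 h; on this read-out lower numbers stand for stronger inhibition and higher numbers for weaker inhibition.
Compound 2 `Cc1ccc(S(=O)(=O)n2cc(COC3=C/C(=N\c4ccc(F)cc4)c4ccccc4C3=O)nn2)cc1` gives 7700 nM in this assay.

Of the compounds shown here, two have been measured so far, and they differ only at one position on the aromatic ring attached to the imine nitrogen. The step of a 1.4-fold higher number from compound 1 to compound 2 (0.15 log units; within the scatter) is too small to count as a real change, so on these numbers compound 2 and compound 1 cannot be set apart; compound 2 simply has its own reading next to one close neighbour.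

Compound 3 `Cc1ccc(S(=O)(=O)n2cc(COC3=C/C(=N\c4ccccc4)c4ccccc4C3=O)nn2)cc1` takes this one step further: hydrogen in place of fluoro on an aromatic carbon. Where the earlier step exchanged one substituent for another at the same place, this one removes the substituent altogether. For the measured compounds named here, the only measured step that speaks to this position, a 1.4-fold higher number from compound 1 to compound 2 (0.15 log units; within the scatter), stayed within the scatter, which suggests that this position tolerates variation without a clear shift in this assay. No step beyond the scatter is therefore expected. The step of a 1.0-fold higher number from compound 2 to compound 3 (0.02 log units; within the scatter) is the estimate that follows. For compound 3 the expected value is 8000 nM, within a range from 3500 nM to 18000 nM.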

Compound 3, half-maximal inhibitory concentration: 12200 nM
Estimate against measurement, compound 3: 1.5-fold (0.18 log units) below; the measured number falls inside the stated range.
By their numbers in this assay, from the lowest: compounds 1, 2 and 3 (each within the scatter of the next, the first and the last beyond it).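

In this assay, the step that removes the fluoro group, a 1.6-fold higher number from compound 2 to compound 3 (0.20 log units; within the scatter), stays inside the scatter, so 4-fluorophenyl and phenyl cannot be told apart on these numbers. For the compounds shown here, the comparison with the bromo compound reads differently: a 2.3-fold higher number from compound 1 to compound 3 (0.35 log units; beyond the scatter) is the first step at this position to pass beyond the scatter, and although it is modest, it shows that the position is not entirely indifferent to what sits there, even though compound 2 cannot be separated from either neighbour. Nothing available here accounts for the gap between bromo and hydrogen at this place.

Going by these compounds, with only bromo, fluoro and hydrogen on this aromatic carbon, it remains open whether a different kind of group, such as a methoxy group, an amine or a carboxylic acid, would move the number further in either direction. On these data alone, it is also open whether the small gap seen here would hold up with a chloro group or a methyl group at the same place, or would prove specific to bromo.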